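The compounds below may be only part of what the source reports. "The series", "measured", "known", "first", "only" and "open" are said of these compounds alone.

Measured so far:
compound 1 `O=C(Nc1ccnnc1)c1cc(N2C[C@H]3COC[C@H]3C2)ccc1OCc1ccccc1` — 50.1 nM
compound 2 `O=C(Nc1ccnnc1)c1cc(N2CCCCC2)ccc1OCc1ccccc1` — 25.1 nM
compound 3 `O=C(Nc1ccnnc1)c1cc(N2CCNCC2)ccc1OCc1ccccc1` — 15.9 nM

In an assay on Sf9 cells for inhibition of Leucine-rich repeat serine/threonine-protein kinase 2 (Homo sapiens), read by TR-FRET, with stated times of 30 min and 2 h (on this read-out lower numbers stand for stronger inhibition and higher numbers for weaker inhibition), compound 3 gives the lowest of the three numbers: compound 2 sits within the scatter of it, while a 3.2-fold lower number from compound 1 to compound 3 (0.50 log units; beyond the scatter) lies beyond it. Compound 4 `CN1CC2(CCN(c3ccc(OCc4ccccc4)c(C(=O)Nc4ccnnc4)c3)CC2)C1` carries a change on that same aromatic carbon: a group of 10 heavy atoms (8 carbon, 2 nitrogen; one four-membered non-aromatic ring with 1 hetero atom, one six-membered non-aromatic ring with 1 hetero atom) in place of a group of 6 heavy atoms (4 carbon, 2 nitrogen; one six-membered non-aromatic ring with 2 hetero atoms), on an aromatic carbon. Among the measured compounds shown here, two measured steps bear on this position. a 1.6-fold lower number from compound 2 to compound 3 (0.20 log units; within the scatter) is within the scatter, whereas a 3.2-fold lower number from compound 1 to compound 3 (0.50 log units; beyond the scatter) shows that the larger two-ring group of compound 1 gave the higher number. Since the entering group is larger still, compound 4 is expected to give a somewhat higher number than compound 3, a 2.0-fold higher number from compound 3 to compound 4 (0.30 log units; within the scatter), modest and uncertain. The estimate for compound 4 in this assay is 32 nM, with a range from 10 nM to 100 nM.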

Compound 4, half-maximal inhibitory concentration: 63.1 nM
Estimate against measurement, compound 4: 2.0-fold (0.29 log units) below; the measured number falls inside the stated range.
By their numbers in this assay, from the lowest: compounds 3, 2, 1 and 4 (each within the scatter of the next, the first and the last beyond it).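

In this assay, among the compounds shown here, the group with a four-membered and a six-membered ring is the first on this aromatic carbon to separate beyond the scatter from both single-ring groups, with a 4.0-fold higher number from compound 3 to compound 4 (0.60 log units; beyond the scatter) and a 2.5-fold higher number from compound 2 to compound 4 (0.40 log units; beyond the scatter). It cannot be told apart from the other two-ring group, with a 1.3-fold higher number from compound 1 to compound 4 (0.10 log units; within the scatter). Nothing available gives a reason for these steps. The compounds shown leave open how a morpholin-4-yl or a dimethylamino group on this carbon would compare with the piperazin-1-yl of compound 3.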